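Methoxy for methyl on a weakly cytotoxic amidrazone

The compounds below may be only part of what the source reports. "The series", "measured", "known", "first", "only" and "open" are said of these compounds alone.

Compound 1 `Cc1ccc(N2CCN/C2=N\N)cc1`: 9%
Compound 2 `Cc1ccc(N2CCn3c2n[nH]c(=O)c3=N)cc1`: 0%

The two measured compounds were tested in an ADME assay on Vero cells (Chlorocebus sabaeus) for cytotoxicity, with a stated time of 72 h, tested at 50 ug/mL; a lower number here means a weaker effect, a higher number a stronger effect of the compound at the concentration tested. Compound 1 gives 9%, and compound 2 gives 0%; the gap between them lies within the scatter, so both show only a weak effect at the concentration tested.

Compound 3 `COc1ccc(N2CCN/C2=N\N)cc1` is not yet measured. It differs from compound 1 by methoxy in place of methyl on an aromatic carbon. Among the measured compounds shown here, no step between measured compounds that differ in one place is known here. A change of this size at that position is expected to leave the read-out in this assay essentially unchanged, with the step from compound 1 to compound 3 estimated as a number 1 percentage points lower from compound 1 to compound 3 (within the scatter), no larger than the scatter in either direction. Compound 3 is therefore expected to give 8%, in the range 0% to 20%.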

Compound 3, a percentage reported as inhibition, at one concentration (the size of the read-out at that concentration, not a potency): 0%
For compound 3 the middle estimate is 8 percentage points above the measured one, and the stated range covers the measured number.
By their numbers in this assay, from the lowest: compounds 2, 3 and 1 (each within the scatter of the next).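

In this assay, among the compounds shown here, the first single-place step on this core, methoxy in place of methyl para to the group of 7 heavy atoms, gives a number 9 percentage points lower from compound 1 to compound 3 (within the scatter), so this exchange on the aromatic carbon does not separate compound 3 from compound 1. The added oxygen and its hydrogen-bond acceptor thus bring no change beyond the scatter in this read-out. Nothing available bears on the reason for this result. Open, on these data alone, is how an amine, a carboxylic acid or a longer chain at this place would read, and whether any group there could give a clear cytotoxic effect.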